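Methyl for 3-methoxybenzyl on the amine nitrogen

This account rests on a few compounds, and the source may have more. Where it says the series, first, only, none or still open, it means among the compounds named here.

The series shares the core of compound 1 `C#CCN(CCCOc1ccc2ccc(=O)oc2c1)Cc1ccccc1`, which in an assay on isolated protein for inhibition of Amine oxidase [flavin-containing] B (Homo sapiens), read by fluorescence and Amplex Red, with stated times of 15 min and 20 min (on this read-out lower numbers stand for stronger inhibition and higher numbers for weaker inhibition), gives 3740 nM. Compound 3 `C#CCN(CCCOc1ccc2ccc(=O)oc2c1)Cc1cccc(OC)c1` gives 4590 nM, the highest of the three numbers, with compound 1 nearest at a 1.2-fold higher number from compound 1 to compound 3 (0.09 log units; within the scatter). Compound 2 `C#CCN(C)CCCCOc1ccc2ccc(=O)oc2c1` gives 27 nM, the lowest number of the set and far beyond the scatter from compound 3.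

Compound 4 `C#CCN(C)CCCOc1ccc2ccc(=O)oc2c1` is not yet measured. It differs from compound 3 by hydrogen in place of 3-methoxyphenyl on a saturated chain carbon bound to an amine nitrogen. No measured step covers exactly this change; the one step shown, from compound 1 to compound 3 at a 1.2-fold higher number from compound 1 to compound 3 (0.09 log units; within the scatter), only tells that the methoxy on the ring barely moves the number. Compound 2, which also bears a methyl on its amine nitrogen, stands far below compound 3, so a large step downward is expected in this assay for compound 4, roughly a 57-fold lower number from compound 3 to compound 4 (1.76 log units; beyond the scatter). Compound 4 is therefore estimated at 80 nM, within 15 nM to 500 nM.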

Compound 4, half-maximal inhibitory concentration: 1090 nM
For compound 4 the middle estimate is 14-fold (1.13 log units) below the measured one; measured number above the stated range.
By their numbers in this assay, from the lowest: compound 2; then compound 4; then compounds 1 and 3 (each within the scatter of the next).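

Within this assay, methyl on the amine nitrogen in place of an aromatic benzyl group gives only modest steps, a 4.2-fold lower number from compound 3 to compound 4 (0.62 log units; beyond the scatter) and a 3.4-fold lower number from compound 1 to compound 4 (0.54 log units; beyond the scatter), so removing the ring alone does not reach the low number of the methyl-bearing compound with the longer chain. With methyl held on the nitrogen, the chain change alone gives a large step, a 40-fold higher number from compound 2 to compound 4 (1.61 log units; beyond the scatter), which places chain length as a stronger handle on this read-out than the change from benzyl to methyl in these compounds. Nothing at hand gives a reason for either step.

Open, as far as these compounds go, is whether a 3-methoxybenzyl group on the amine nitrogen would be tolerated on the longer chain of compound 2. Also open, from the compounds shown here alone, are an ethyl group on that nitrogen and a chain longer than that of compound 2.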